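The source may report more compounds than this note shows. Statements on the series, on what has been measured and on what is new or still open speak of the compounds shown alone.

Compound 1 `CCCOC(=O)N1N=C(c2cccc(OC)c2)CC1c1cc(OC)c(OC)c(OC)c1`: > 10000 nM
Compound 2 `CCOC(=O)N1N=C(c2ccc(OC)cc2)CC1c1cc(OC)c(OC)c(OC)c1`: 9270 nM

Within the data shown here, in a functional assay on A2780 cells (Homo sapiens) for antiproliferative activity, read by MTT assay, with a stated time of 48 h (on this read-out higher numbers stand for weaker inhibition of growth and lower numbers for stronger inhibition of growth), compound 2 gives the only actual number so far, 9270 nM. Compound 1 is reported as > 10000 nM, which is a limit of the assay and not a number.

Compound 3 `CCCOC(=O)N1N=C(c2ccc(OC)cc2)CC1c1cc(OC)c(OC)c(OC)c1` is built from compound 2 by one small change, methyl in place of hydrogen on a saturated chain carbon, two bonds along the chain from an oxygen next to a carbonyl group: the ethoxy group becomes propoxy. Among the measured compounds shown here, no measured pair shows what this change does in this assay, so the expectation rests on compound 2 alone. With compound 2 at 9270 nM, growth inhibition is already weak, and a small shift toward weaker inhibition, hardly beyond the usual scatter, seems most likely. The expected step is a 1.3-fold higher number from compound 2 to compound 3 (0.11 log units; within the scatter). For compound 3 the estimated value is 12000 nM, with an expected range from 5000 nM to 30000 nM.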

Compound 3, concentration for 50% growth inhibition: 11700 nM
Estimate against measurement, compound 3: 1.0-fold (0.01 log units) above; the range from low to high includes it.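

Among these compounds, this is the first measured pair at this position: in this assay, methyl in place of hydrogen on a saturated chain carbon, two bonds along the chain from an oxygen next to a carbonyl group, gives a 1.3-fold higher number from compound 2 to compound 3 (0.10 log units; within the scatter). Compound 2 and compound 3 therefore cannot be told apart in this test, so going from ethoxy to propoxy has no readable effect on growth inhibition here. This holds for this one pair only, in a part of the series where growth inhibition is weak.

Going by these compounds, the swap of 4-methoxyphenyl for 3-methoxyphenyl stays open, because the step between compound 1 and compound 3 cannot be read, as compound 1 is reported only as a limit: the limit of > 10000 nM in this assay, at which 1 of the 3 values shown sits. Also open is whether a longer chain such as butoxy, or an amine at the end of the chain, would move the number beyond the usual scatter.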